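This account rests on a few compounds, and the source may have more. Where it says the series, first, only, none or still open, it means among the compounds named here.

Compound 1, `Nc1ccccc1NC(=O)/C=C/c1ccc(Cn2cnc3c(Nc4cccc(Cl)c4)nc(Cl)nc32)cc1`: 35.8%
Compound 2, `CCCCn1cnc2c(Nc3ccccc3)nc(NCOCc3ccc(/C=C/C(=O)Nc4ccccc4N)cc3)nc21`: 27.9%
Compound 3, `Nc1ccccc1NC(=O)c1ccc(CNc2nc(Cl)nc3c2ncn3Cc2ccccc2)cc1`: 5.01%

In a functional assay on HepG2 cells (Homo sapiens) for antiproliferative activity, read by CCK-8 assay, with a stated time of 72 h, tested at 2 uM (a higher number here means a stronger effect of the compound at the concentration tested, a lower number a weaker effect), compound 3 gives the lowest of the three numbers; compound 2 and compound 1 both lie above it by more than the usual scatter. Compound 4, `COC(CCn1cnc2c(NCc3ccc(C(=O)Nc4ccccc4N)cc3)nc(Cl)nc21)OC`, differs from compound 3 in one place: 2,2-dimethoxyethyl in place of phenyl on a saturated chain carbon bound to an aromatic nitrogen. Among the measured compounds shown here, no two measured compounds differ in only one place, so the size of this kind of step cannot be read from a neighbouring pair. For the measured compounds named here, with nothing among the measured compounds to show what a change at this carbon does, the step is expected to be small and to stay within the scatter, an expected a number 5 percentage points higher from compound 3 to compound 4 (within the scatter). Compound 4 is therefore estimated at 10%, with a range from 0% to 30%.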

Compound 4, a percentage reported as inhibition, at one concentration (the size of the read-out at that concentration, not a potency): 8.52%
For compound 4 the middle estimate is 1.5 percentage points above the measured one; low and high end bracket the measured number.
By their numbers in this assay, from the lowest: compounds 3 and 4 (each within the scatter of the next); then compounds 2 and 1 (each within the scatter of the next).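

In this assay the change from phenyl to 2,2-dimethoxyethyl on a saturated chain carbon bound to an aromatic nitrogen, a number 3.5 percentage points higher from compound 3 to compound 4 (within the scatter), shows that this position can lose its aromatic ring and gain two hydrogen-bond acceptors without a reading that stands clear of the scatter. Nothing measured bears on why the two compounds read alike.

Going by these compounds, what remains open is whether any group at this position would move the number beyond the scatter. An amine or a carboxylic acid in place of the two methoxy groups would test that.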